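The source may report more compounds than this note shows. Statements on the series, on what has been measured and on what is new or still open speak of the compounds shown alone.

Working notes on the series. Compound 1 `COc1ccccc1S(=O)(=O)/C=C/c1ccccn1` in an ADME assay on microsomes from liver (Homo sapiens) for metabolic stability, read by LC-MS, using NADPH, with stated times of 5 min and 30 min, tested at 1 uM (a lower number here means that less of the compound is left, a higher number that more of the compound is left), gives 91%. Compound 3 `COc1ccccc1S(=O)(=O)/C=C/c1cccnc1` differs from compound 1 by pyridin-3-yl in place of pyridin-2-yl on a double-bonded chain carbon bound to a double-bonded chain carbon; in this assay compound 3 gives 97%, and the step is a number 6 percentage points higher from compound 1 to compound 3 (within the scatter). Compound 2 `COc1cccc(S(=O)(=O)/C=C/c2ccccn2)c1` carries a different core; how the cores of compound 1 and compound 2 differ is not broken down here. In this assay compound 2 gives 74%, the lowest of the three numbers, and its gaps to compound 1 and to compound 3 both lie beyond the scatter.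

Compound 4 `COc1cccc(S(=O)(=O)/C=C/c2cccnc2)c1` has not yet been measured. It differs from compound 2 by pyridin-3-yl in place of pyridin-2-yl on a double-bonded chain carbon bound to a double-bonded chain carbon, which is the same change as that from compound 1 to compound 3, made at the same place. Among the compounds with values here, a step of similar size, a number 5 percentage points higher from compound 2 to compound 4 (within the scatter), is expected from compound 2 to compound 4, because a number 6 percentage points higher from compound 1 to compound 3 (within the scatter) is the only measured instance of this change and it stayed within the scatter. Compound 4 is thus estimated at 79% in this assay, with a likely span from 66% to 90%, pending measurement.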

Compound 4, percent of the compound remaining: 75%
Estimate against measurement, compound 4: 4 percentage points above; the measured number falls inside the stated range.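

In this assay, pyridin-3-yl in place of pyridin-2-yl on a double-bonded chain carbon bound to a double-bonded chain carbon gives a number 1 percentage points higher from compound 2 to compound 4 (within the scatter), so on this core too the change stays inside the usual spread of the read-out. Set beside the earlier step, the change carries from one core to the other with no difference that can be told apart: the same change on two cores in this assay, a number 6 percentage points higher (within the scatter) from compound 1 to compound 3 and a number 1 percentage points higher (within the scatter) from compound 2 to compound 4, 5 percentage points apart, within the scatter of two such steps. This rests on two pairs only, so it shows that the change made no visible difference on these two cores, but it does not show that the same would hold on any other core or in any other assay.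

The compounds shown leave open how far the core alone accounts for the printed values of compound 3 at 97% and compound 4 at 75%. Also open, from the compounds shown here alone, is what an amine or a carboxylic acid in place of the pyridinyl groups, at that same place, would give in this assay.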